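Methoxyphenyl ethyl thioether in the pyrazolopyrimidinone series

A few compounds are considered here, and "the series" means these few. Any claim that something is new, unique, unknown or untested is made for them only; others in the source may bear on it.

Measured so far:
compound 1 `C[C@@H](Sc1nc2c(cnn2C)c(=O)n1-c1ccccc1)c1ccccc1` — 40 nM
compound 2 `CC(Sc1nc2c(cnn2C)c(=O)n1-c1ccccc1)c1ccccn1` — 63 nM

Compound 2 holds the higher of the two numbers in an assay on isolated protein for inhibition of retinal dehydrogenase 2 (Homo sapiens) (a lower number here means a stronger inhibitor, a higher number a weaker inhibitor), and its nearest neighbour is compound 1, from which it is separated only by a 1.6-fold higher number from compound 1 to compound 2 (0.20 log units; within the scatter). That single step exchanged the 1-phenylethyl group on the sulfur for 1-(pyridin-2-yl)ethyl and did not move the number beyond the scatter.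

Compound 3 `COc1cccc(C(C)Sc2nc3c(cnn3C)c(=O)n2-c2ccccc2)c1` is not yet measured. It differs from compound 2 in one place: 3-methoxyphenyl in place of pyridin-2-yl on a saturated chain carbon bound to a saturated chain carbon and a sulfur. Within the data shown here, the only step that bears on this is the one from compound 1 to compound 2, which exchanged a six-membered ring at the same position and stayed within the scatter. Among the measured compounds shown here, no measured compound carries a methoxy group, so the added substituent has no precedent here. On the evidence of the phenyl-to-pyridinyl exchange alone, the expectation for the return to a carbon-only ring is a step of a 1.4-fold lower number from compound 2 to compound 3 (0.15 log units; within the scatter) in this assay, not beyond the scatter. Compound 3 is therefore expected to give about 45 nM, within a range from 15 nM to 150 nM.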

Compound 3, half-maximal inhibitory concentration: 108 nM
Compound 3: the middle estimate sits 2.4-fold (0.38 log units) below what was measured, within the range that was stated.
By their numbers in this assay, from the lowest: compounds 1, 2 and 3 (each within the scatter of the next, the first and the last beyond it).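

Replacing pyridin-2-yl with 3-methoxyphenyl on a saturated chain carbon bound to a saturated chain carbon and a sulfur gives, in this assay, a 1.7-fold higher number from compound 2 to compound 3 (0.23 log units; within the scatter) and so no separation between the two compounds. Among these compounds, this is the first ring to carry a substituent at this position, and compound 3 shows that a methoxy group can be present on the ring without a step beyond the scatter from compound 2, extending what the bare-ring exchange between compound 1 and compound 2 could show. Nothing available explains the result or links it to any measured property of either group.

A single methoxy compound does not show whether 2-methoxyphenyl or 4-methoxyphenyl would read the same, or whether a larger or charged substituent on the ring, such as a dimethylamino group or a carboxylic acid, would remain within the scatter of compound 3. Also open, as far as these compounds go, is what a longer chain in place of the methyl on the saturated chain carbon would do, and how the two mirror-image forms of compound 3 would compare in this assay.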